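Phenyl-bearing oxazolopyridines: whole-organism inhibition at one dose

The source may hold more compounds than are shown below. What is called first, only, known or untested is meant among the compounds shown, and "the series" means these compounds.

Two measured members of this series carry the same core and differ only in what sits on the phenyl ring. Compound 1 `COc1ccccc1-c1nc2ncccc2o1` gives 9% in a functional assay on the whole organism for inhibition, with Rattus norvegicus as the target, at a dose of 30 mg/kg; on this read-out higher numbers stand for more inhibition at the one dose given (going by the name of the read-out) and lower numbers for less inhibition. Compound 2 `FC(F)(F)Oc1ccc(-c2nc3ncccc3o2)cc1` gives 0% in this assay. Compound 2 stands at the low end of the two numbers, but its gap to compound 1 is within the usual scatter, so the two cannot be told apart on these data. Nothing in either number points to a sizeable effect at the dose used.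

Compound 3 `c1ccc(-c2nc3ncccc3o2)cc1` has not yet been measured. Relative to compound 2 the change is hydrogen in place of trifluoromethoxy on an aromatic carbon. Given that neither measured compound reached a clear effect, the step from compound 2 to compound 3 is expected to be small, a number 5 percentage points higher from compound 2 to compound 3 (within the scatter), and not beyond the scatter in either direction. Compound 3 is therefore estimated at 5% in this assay, with a range from 0% to 20%.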

Compound 3, a percentage reported as inhibition, in the whole organism at one dose (the size of the read-out at that dose, not a potency): 41%
Estimate against measurement, compound 3: 36 percentage points below, and the stated range ends below it.
By their numbers in this assay, from the lowest: compounds 2 and 1 (each within the scatter of the next); then compound 3.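

In this assay, going by these compounds alone, the bare phenyl ring is the first member of the series with a clear effect: hydrogen in place of trifluoromethoxy gives a number 41 percentage points higher from compound 2 to compound 3 (beyond the scatter) and hydrogen in place of methoxy gives a number 32 percentage points higher from compound 1 to compound 3 (beyond the scatter) as the second step of the same direction. The earlier pair lay within the scatter of each other and gave no sign that the phenyl ring could matter, whereas both steps now lie beyond the scatter and compound 3 stands clear of compound 1 and compound 2. Nothing at hand bears on the cause of these steps.

Open, going by these compounds, is whether a single fluorine, a methyl or an amine on the same aromatic carbon keeps the number of compound 3 or loses it. Also open, on these data alone, is whether a carboxylic acid or a longer chain is compatible with any effect, and how compound 3 behaves at other doses.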